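The source may report more compounds than this note shows. Statements on the series, on what has been measured and on what is new or still open speak of the compounds shown alone.

Measured compounds:
- compound 1, `COc1ccc(CNC(=O)c2c(NC(=O)C(F)(F)F)sc3c2CCCCC3)cc1`: > 50000 nM
- compound 2, `COc1ccc(NC(=O)c2c(NC(=O)C(F)(F)F)sc(C)c2C)cc1`: > 50000 nM
- compound 3, `CC(C)(C)OC(=O)c1c(N)sc2c1CCCCC2`: > 50000 nM

These three compounds were tested in an ADME assay on THP-1 cells (Homo sapiens) for cytotoxicity; a higher number here means that more compound is tolerated, a lower number that less compound is tolerated. For compound 1 the value > 50000 nM is not a number but a limit of the assay, meaning no cytotoxic effect was seen up to the highest concentration tried. The same holds for compound 2, whose value > 50000 nM is also a limit. Compound 3 likewise gives only a limit, > 50000 nM. So compound 1 does not stand above or below the others; all three sit together at the limit of > 50000 nM in this assay, at which 3 of the 3 values shown sit.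

The next compound, compound 4, `N#Cc1ccc(NC(=O)c2c(NC(=O)C(F)(F)F)sc3c2CCCCC3)cc1`, has not yet been measured in this assay . It differs from compound 1 in one place: 4-cyanophenyl in place of 4-methoxybenzyl on an amide-type nitrogen. The shared core, the trifluoroacetyl amide and the carboxamide carbonyl stay the same.

For the measured compounds named here, nothing among the measured compounds shows a step in this assay , so there is no measured change to lean on. With compound 1, compound 2 and compound 3 all at the limit, the expectation is that compound 4 will stay in the same tolerated region, and the estimated step of a number no higher from compound 1 to compound 4 (the limit leaves the size open) is none beyond the scatter. Compound 4 is therefore estimated at 50000 nM, within a range from 20000 nM to 120000 nM, most likely reported again only as a limit.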

Compound 4, half-maximal cytotoxic concentration: 9110 nM
The estimate for compound 4 lay 5.5-fold (0.74 log units) above the measured number; measured number below the stated range.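

In this assay, putting 4-cyanophenyl in place of 4-methoxybenzyl on an amide-type nitrogen gives an at least 5.4-fold lower number from compound 1 to compound 4 (0.73 log units; beyond the scatter), so the group at this place can change how much compound the cells tolerate. From the compounds shown here alone, the true size of this step stays unknown, since compound 1 gives only a limit and the step is a lower bound. Compound 4 is the one compound shown with a real number rather than a limit, so these compounds are not all equally well tolerated in this test: the limit of > 50000 nM in this assay, at which 3 of the 4 values shown sit.

This single swap changes two things at once, the methoxy becoming a nitrile and the benzyl becoming a phenyl, and the compounds shown cannot say which of the two matters, or why the cells tolerate less of compound 4. A 4-cyanobenzyl group on the same nitrogen would separate these two changes, while an amine or a carboxylic acid in place of the nitrile would show whether the nitrile itself is needed for the lower number.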